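From 4-fluorophenyl to 4-methylphenyl on the shared core

The source may hold more compounds than are shown below. What is called first, only, known or untested is meant among the compounds shown, and "the series" means these compounds.

In a functional assay on HUVEC cells (Homo sapiens) for cytotoxicity (on this read-out lower numbers stand for an effect already at smaller amounts and higher numbers for an effect only at larger amounts of compound), compound 1 `COC1=C(C)C(=O)/C(=C(O)/C=C/c2ccc(Br)cc2)C(=O)C1(C)C` gives 3.6 ug/mL and compound 2 `COC1=C(C)C(=O)/C(=C(O)/C=C/c2ccc(F)cc2)C(=O)C1(C)C` gives 2 ug/mL. Among the measured compounds shown here, compound 2 thus stands within the scatter of compound 1, its only measured neighbour so far. For the measured compounds named here, the one measured step is a 1.8-fold lower number from compound 1 to compound 2 (0.26 log units; within the scatter), with fluoro in place of bromo on an aromatic carbon, and it stays within the scatter.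

Still unmeasured is compound 3 `COC1=C(C)C(=O)/C(=C(O)/C=C/c2ccc(C)cc2)C(=O)C1(C)C`. The change is methyl in place of fluoro on an aromatic carbon, para to a large group. Going by the values given here, the fluoro-bromo step is the only measured evidence at this place. Among the compounds with values here, no compound carrying methyl there has a number yet, so the series offers one small step and no direct precedent for this group. On the evidence of a 1.8-fold lower number from compound 1 to compound 2 (0.26 log units; within the scatter), no shift beyond the scatter is expected in this assay, and the expected size is a 1.3-fold higher number from compound 2 to compound 3 (0.10 log units; within the scatter). For compound 3 the estimated value is 2.5 ug/mL, with an expected range from 1 ug/mL to 6 ug/mL.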

Compound 3, concentration for half-maximal effect: 2.4 ug/mL
Estimate against measurement, compound 3: 1.0-fold (0.02 log units) above; the range from low to high includes it.
By their numbers in this assay, from the lowest: compounds 2, 3 and 1 (each within the scatter of the next).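

Methyl is the first group at this place on the aromatic ring, para to a large group, that is not a halogen, and in this assay the step to it stays within the scatter: a 1.2-fold higher number from compound 2 to compound 3 (0.08 log units; within the scatter), and likewise a 1.5-fold lower number from compound 1 to compound 3 (0.18 log units; within the scatter). All three pairs among compound 1, compound 2 and compound 3 now lie within the scatter of one another, so the absence of any readable shift seen for the exchange of one halogen for another also holds for this exchange of fluoro or bromo for methyl. Nothing on hand offers an explanation for why these three compounds read alike.

On these data alone, whether the read-out stays this level with a different kind of group at this place, such as an amine, a carboxylic acid or a longer chain, remains open. Also open is how the read-out responds to changes elsewhere on the shared core, as the three compounds shown differ at this one place only.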